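The source may report more compounds than this note shows. Statements on the series, on what has been measured and on what is new or still open speak of the compounds shown alone.

Two compounds of this series have numbers in an assay on cell membranes for displacement of a labelled ligand from Sigma non-opioid intracellular receptor 1 (Rattus norvegicus); on this read-out lower numbers stand for stronger inhibition and higher numbers for weaker inhibition. Compound 1 `CCC(=O)c1ccc2c(c1)sc(=O)n2CCCCCCN1CCCCCC1` gives 10.4 nM in this assay. Compound 2 `CCCC(=O)c1ccc2c(c1)sc(=O)n2CCCCN1CCCCCC1` gives 4.8 nM in this assay, the lower of the two numbers, and its gap to compound 1 lies beyond the scatter. Within the data shown here, compound 1 and compound 2 differ in two places at once, so no single step between them can be read. Compound 3 `CCCC(=O)c1ccc2c(c1)sc(=O)n2CCCCCCN1CCCCCC1` is the next compound, not yet measured in this assay. It differs from compound 2 by 2-(azepan-1-yl)ethyl in place of azepan-1-yl on a saturated chain carbon, four bonds along the chain from an aromatic nitrogen. Compound 1 carries the same chain length as compound 3 and sits a little higher than compound 2, which is the only hint available; a small step is expected, a 1.7-fold higher number from compound 2 to compound 3 (0.22 log units; within the scatter), toward a somewhat higher number, likely within the scatter. Compound 3 is accordingly estimated at 8 nM in this assay, with a range from 3 nM to 20 nM.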

Compound 3, inhibition constant: 10.8 nM
Compound 3: the middle estimate sits 1.4-fold (0.13 log units) below what was measured; the range from low to high includes it.
By their numbers in this assay, from the lowest: compound 2; then compounds 1 and 3 (each within the scatter of the next).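

In this assay, among these compounds, the first readable single change on the chain, 2-(azepan-1-yl)ethyl in place of azepan-1-yl on a saturated chain carbon, four bonds along the chain from an aromatic nitrogen, gives a 2.3-fold higher number from compound 2 to compound 3 (0.35 log units; beyond the scatter) and thus a modest loss of inhibition. Methyl in place of hydrogen on a saturated chain carbon, two bonds along the chain from a carbonyl carbon, gives a 1.0-fold higher number from compound 1 to compound 3 (0.02 log units; within the scatter) on the longer chain, so of the two readable changes only the one near the azepane ring moves the number beyond the scatter. Nothing at hand bears on why the chain step has this size.

Open, from the compounds shown here alone, is whether the methyl step reads the same on the shorter chain. Also open, going by these compounds, is how piperidin-1-yl or morpholin-4-yl in place of azepan-1-yl would read on either chain.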